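The source may report more compounds than this note shows. Statements on the series, on what has been measured and on what is new or still open speak of the compounds shown alone.

Compound 1 `C/C(=N\OCC(N)=O)c1ccc(Cl)cc1`, compound 2 `C/C(=N\OCCC(=O)O)c1ccc(Cl)cc1` and compound 3 `C/C(=N\OC(C)C(=O)O)c1ccc(Cl)cc1` share one core and differ only in the chain carried on an oxygen. In a functional assay on the whole organism for inhibition, with Rattus norvegicus as the target, read by paw edema, with stated times of 1 h and 3 h (a lower number here means that less compound is needed, a higher number that more compound is needed for the effect), compound 1 gives 24 mg/kg and compound 2 gives 80 mg/kg while compound 3 gives 55 mg/kg on the same scale. Compound 3 therefore sits together with compound 2 at the higher-number end of this small set. Putting 1-carboxyethyl in place of 2-carboxyethyl gave a 1.5-fold lower number from compound 2 to compound 3 (0.16 log units; within the scatter) and so did not separate them. Only compound 1 stands apart, with a 2.3-fold higher number from compound 1 to compound 3 (0.36 log units; beyond the scatter) and a 3.3-fold higher number from compound 1 to compound 2 (0.52 log units; beyond the scatter) as modest steps.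

Compound 4 `C/C(=N\OC(C)(C)C(=O)O)c1ccc(Cl)cc1` keeps the chain of compound 3 and makes one change: methyl in place of hydrogen on a saturated chain carbon bound to a carbonyl carbon, an oxygen and a saturated chain carbon is the whole difference. Among the compounds with values here, no measured step adds this methyl, so the evidence is indirect. The closest guide is the change between the two carboxyethyl chains, which gave a 1.5-fold lower number from compound 2 to compound 3 (0.16 log units; within the scatter) as its small result. In this assay a similarly small step is therefore expected, with no clear direction and nothing beyond the scatter. The expected step is no change at the digits printed from compound 3 to compound 4 (within the scatter) in this estimate. For compound 4 the estimated value is 55 mg/kg with an expected range from 25 mg/kg to 120 mg/kg as its likely span.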

Compound 4, dose for half-maximal effect: 42 mg/kg
Estimate against measurement, compound 4: 1.3-fold (0.12 log units) above, within the range that was stated.
By their numbers in this assay, from the lowest: compounds 1, 4, 3 and 2 (each within the scatter of the next, the first and the last beyond it).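

Within the data shown here, this is the first direct reading of methyl in place of hydrogen on a saturated chain carbon bound to a carbonyl carbon, an oxygen and a saturated chain carbon. In this assay, the change gave a 1.3-fold lower number from compound 3 to compound 4 (0.12 log units; within the scatter), so the two compounds cannot be told apart, and this carbon can carry the added methyl without a measurable effect on the dose needed in the rat. Nothing in the data shown explains this result.

A single methyl is a small probe, however, and the result says nothing about what ethyl, a longer chain or a hydroxyl group would do on the same carbon, where a larger effect in either direction remains possible. It also remains open whether the carbamoyl end of compound 1, placed on the chain of compound 4 in place of the carboxylic acid, would give a number nearer to that of compound 1, since no pair shown isolates that change on this chain.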